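Working notes: shortening the amide-bearing chain on the ring amine

The source may hold more compounds than are shown below. What is called first, only, known or untested is meant among the compounds shown, and "the series" means these compounds.

Measured so far, with an assay on AV12 cells for binding affinity to Neuropeptide Y receptor type 1 (Homo sapiens); on this read-out higher numbers stand for weaker inhibition and lower numbers for stronger inhibition:
- compound 1 `Cc1cccc2c1nc(COc1ccc(Cl)cc1)n2CCCC1CCN(C)CC1` gives 52 nM
- compound 2 `Cc1cccc2c1nc(COc1ccc(Cl)cc1)n2CCCC1CCN(Cc2ccccc2)CC1` gives 109 nM
- compound 3 `Cc1cccc2c1nc(COc1ccc(Cl)cc1)n2CCCC1CCN(CCCC(=O)N2CCCCC2)CC1` gives 21 nM

Compound 3 holds the lowest number of the three; its steps to the others, a 2.5-fold lower number from compound 1 to compound 3 (0.39 log units; beyond the scatter) and a 5.2-fold lower number from compound 2 to compound 3 (0.72 log units; beyond the scatter), both lie beyond the scatter. Compound 4 `Cc1cccc2c1nc(COc1ccc(Cl)cc1)n2CCCC1CCN(CC(=O)N2CCCCC2)CC1` differs from it by (piperidin-1-yl)carbonyl in place of 2-((piperidin-1-yl)carbonyl)ethyl on a saturated chain carbon bound to an amine nitrogen in a ring. For the measured compounds named here, no measured pair tests this chain length directly; the steps bearing on it are the two above, which show that attaching this amide-bearing substituent lowered the number. A step near the scatter, if anything slightly upward, is expected in this assay, a 1.5-fold higher number from compound 3 to compound 4 (0.18 log units; within the scatter). Compound 4 is therefore estimated at 32 nM, within 10 nM to 100 nM.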

Compound 4, inhibition constant: 136 nM
For compound 4 the middle estimate is 4.3-fold (0.63 log units) below the measured one; measured number above the stated range.
By their numbers in this assay, from the lowest: compound 3; then compound 1; then compounds 2 and 4 (each within the scatter of the next).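

Chain length at this position matters: with the shorter ((piperidin-1-yl)carbonyl)methyl on the ring amine, the benefit of the amide-bearing substituent disappears (a 6.5-fold higher number from compound 3 to compound 4 (0.81 log units; beyond the scatter)). Hydrogen on that chain carbon now gives the lower number (a 2.6-fold higher number from compound 1 to compound 4 (0.42 log units; beyond the scatter)), while phenyl and (piperidin-1-yl)carbonyl there cannot be told apart (a 1.2-fold higher number from compound 2 to compound 4 (0.10 log units; within the scatter)). No evidence at hand accounts for the loss.

From the compounds shown here alone, a longer chain than 3-((piperidin-1-yl)carbonyl)propyl remains open. So does whether a carboxylic acid or a simple amine at the chain end would match the piperidinyl amide.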